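A Fluorophenyl Ring in Place of a Hydroxymethyl Group

The compounds below may be only part of what the source reports. "The series", "measured", "known", "first", "only" and "open" are said of these compounds alone.

Compound 1 `Cc1cc(CO)nc(NNC(=O)Nc2cc(Cl)nc(Cl)c2)c1` is one of two urea compounds examined in a functional assay on CHO cells for antagonist activity at sphingosine 1-phosphate receptor 2 (Homo sapiens), read by scintillation counting and GTPgammaS binding, with a stated time of 4 h, in the presence of a further agent that is not named here; a higher number here means a weaker inhibitor, a lower number a stronger inhibitor. In that assay compound 1 gives 31 nM, the higher of the two numbers recorded so far. Compound 2 `Cc1cc(NNC(=O)Nc2cc(Cl)nc(Cl)c2)ncc1-c1ccn(C)n1` bears a different substitution pattern on the shared core, and in this assay compound 2 gives 9.3 nM. For the measured compounds named here, the gap between these two values lies beyond the usual scatter, so compound 2 is the stronger inhibitor of the pair; no single-point step joins the two structures, and nothing more than their two values is said here.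

Compound 3 `Cc1cc(NNC(=O)Nc2cc(Cl)nc(Cl)c2)nc(-c2ccc(F)cc2)c1` has not yet been measured. It differs from compound 1 in one place: 4-fluorophenyl in place of hydroxymethyl on an aromatic carbon. Going by the values given here, no measured step exists for this kind of change, so the expectation rests on the two values alone. A moderate step towards a lower number is expected in this assay, though one that may still fall within the scatter. Compound 3 is estimated at 15 nM, with a range from 4 nM to 60 nM. The expected step is a 2.1-fold lower number from compound 1 to compound 3 (0.32 log units; beyond the scatter).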

Compound 3, half-maximal inhibitory concentration: 6.2 nM
The estimate for compound 3 lay 2.4-fold (0.38 log units) above the measured number; measured number inside the range.
By their numbers in this assay, from the lowest: compounds 3 and 2 (each within the scatter of the next); then compound 1.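

For the compounds shown here, the aromatic carbon next to the ring nitrogen, which the earlier compounds showed carrying only hydroxymethyl, also accepts a far larger group, and in this assay the change to 4-fluorophenyl gives a 5.0-fold lower number from compound 1 to compound 3 (0.70 log units; beyond the scatter) with a size that lies beyond the usual scatter. The change removes the hydrogen-bond donor and acceptor of hydroxymethyl and brings in a six-membered aromatic ring, yet the number falls, so a low number at this carbon does not depend on that donor or acceptor being present. No measurement at hand gives a reason for this step.

This one step changes size, ring content, hydrogen-bonding groups and the presence of fluorine all at once, so it cannot say which of these matters, and only a group such as unsubstituted phenyl, methoxymethyl or a plain methyl at the same carbon could begin to pull them apart. On these data alone, whether the fluorine could sit elsewhere on the ring, as in 3-fluorophenyl, and whether a ring holding nitrogen, such as pyridyl, would read the same in this assay also remain open.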